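Working notes: compound 1 to compound 4

This account rests on a few compounds, and the source may have more. Where it says the series, first, only, none or still open, it means among the compounds named here.

Measured in a functional assay on OVCAR-3 cells (Homo sapiens) for antiproliferative activity, read by MTT assay, with a stated time of 24 h; on this read-out lower numbers stand for stronger inhibition and higher numbers for weaker inhibition:
- compound 1 `Cc1ccccc1NNC(=O)c1ccc(NS(=O)(=O)c2cnc(O)nc2O)cc1`: > 20000 nM (a limit)
- compound 2 `Cc1ccccc1NNC(=O)c1cccc(NS(=O)(=O)c2cnc(O)nc2O)c1`: > 20000 nM (a limit)
- compound 3 `O=C(NNc1ccccc1Cl)c1cccc(NS(=O)(=O)c2cnc(O)nc2O)c1`: 3350 nM

Compound 1 is reported only as a limit, > 20000 nM. Its sole reference point is therefore (the limit of > 20000 nM in this assay, at which 2 of the 3 values shown sit).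

Compound 4 `Cc1ccccc1C(=O)NNC(=O)c1ccc(NS(=O)(=O)c2cnc(O)nc2O)cc1` is the next to be read. Its difference from compound 1 is (2-methylphenyl)carbonyl in place of 2-methylphenyl on an amine nitrogen. In words, (2-methylphenyl)carbonyl stands in place of 2-methylphenyl on an amine nitrogen.

One measured step is available: an at least 5.9-fold lower number from compound 2 to compound 3 (0.77 log units; beyond the scatter). It is at least modest and beyond the scatter, but it is chloro in place of methyl on an aromatic carbon. Among the measured compounds shown here, that is a different change, and compound 4 keeps the methyl, so it sets no size for this step. For the measured compounds named here, no measured step covers the change at hand, so no clear shift in either direction is expected, and another limit reading is quite possible.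

The expected step is a number no higher from compound 1 to compound 4 (the limit leaves the size open). In this assay, compound 4 is estimated at 20000 nM, with an expected range of 5000 nM to 60000 nM.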

Compound 4, half-maximal inhibitory concentration: > 20000 nM
Compound 4 gave a limit, no number (the forecaster's own chance of this, stated with the estimate: 55%); the middle value sits exactly at the limit.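

In this assay compound 4 gives > 20000 nM, a limit. Compound 1 gives > 20000 nM, also a limit, so the step between the two cannot be read. The compounds shown leave open whether (2-methylphenyl)carbonyl in place of 2-methylphenyl on an amine nitrogen changes the read-out at all.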